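The source may hold more compounds than are shown below. What is called first, only, known or untested is meant among the compounds shown, and "the series" means these compounds.

Measured compounds:
compound 1, `Cc1ccc(OCC(=O)N(Cc2cccs2)CC(C)C)cc1`, 900 nM in an assay on HEK293 cells for agonist activity at transient receptor potential cation channel subfamily M member 8 (Homo sapiens), read by fluorescence and calcium flux, with a stated time of 15 min; a higher number here means that more compound is needed for the effect, a lower number that less compound is needed
compound 2, `CCN(Cc1ccco1)C(=O)COc1ccc(C)cc1`, 489 nM
compound 3, `CCN(Cc1cccs1)C(=O)COc1ccc2c(c1)CCC2`, 0.8 nM

Compound 1 gives the highest number of the three in this assay. Compound 2 lies within the scatter of compound 1, so the two cannot be told apart. Compound 3 gives a far lower number than compound 1, a gap well beyond the scatter.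

Compound 4, `Cc1ccc(OCC(=O)N(Cc2cccs2)c2nccn2C)cc1`, has not yet been measured. It differs from compound 1 in one place: 1-methyl-1H-imidazol-2-yl in place of isobutyl on an amide-type nitrogen. Going by the values given here, no two measured compounds differ from each other in only one spot, so no measured step shows what such a change does.

The step of a 1.7-fold higher number from compound 1 to compound 4 (0.22 log units; within the scatter) is therefore expected to be small, with no clear direction beyond the scatter. Compound 4 is estimated at 1500 nM, with a range from 300 nM to 8000 nM.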

Compound 4, half-maximal effective concentration: 1790 nM
Estimate against measurement, compound 4: 1.2-fold (0.08 log units) below; the measured number falls inside the stated range.
By their numbers in this assay, from the lowest: compound 3; then compounds 2, 1 and 4 (each within the scatter of the next, the first and the last beyond it).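

In this assay, going by these compounds alone, the change from isobutyl to 1-methyl-1H-imidazol-2-yl on the amide-type nitrogen is the first single-place step available, and it gives a 2.0-fold higher number from compound 1 to compound 4 (0.30 log units; within the scatter) and so no difference that can be told from the scatter. This nitrogen therefore carries either an open chain or a five-membered aromatic ring with little visible consequence in this pair. No measurement at hand offers a reason for this result. On these data alone, whether a 2-aminoethyl chain or a phenyl ring would fare the same here remains open. So does whether 1-methyl-1H-imidazol-2-yl in place of ethyl on compound 3 would also give so small a step.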